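Replacing the 2-fluorophenyl group in compound 3

This account rests on a few compounds, and the source may have more. Where it says the series, first, only, none or still open, it means among the compounds named here.

In an ADME assay on HUVEC cells (Homo sapiens) for inhibition, read by CCK-8 assay, with a stated time of 24 h, in the presence of a further agent that is not named here (a higher number here means a weaker inhibitor, a lower number a stronger inhibitor), compound 3 (`O=C1Nc2ccc(F)cc2/C1=C/c1ccc(-c2cn(-c3ccccc3F)nn2)cc1`) gives 14400 nM and compound 1 (`O=C1Nc2ccccc2/C1=C/c1ccc(-c2cn(-c3ccccc3F)nn2)cc1`) gives 19300 nM; these two values lie within the scatter of each other. Compound 2 (`O=C1Nc2ccccc2/C1=C/c1ccc(-c2cn(-c3cccc(Cl)c3)nn2)cc1`) reads > 20000 nM, which is a limit of the assay and not a number.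

Compound 4 (`O=C1Nc2ccc(F)cc2/C1=C/c1ccc(-c2cn(-c3ccc(Cl)c(C(F)(F)F)c3)nn2)cc1`) carries 4-chloro-3-(trifluoromethyl)phenyl in place of 2-fluorophenyl on an aromatic nitrogen. The closest measured change at this place, 3-chlorophenyl in place of 2-fluorophenyl, is an at least 1.0-fold higher number from compound 1 to compound 2 (0.01 log units; that floor lies within the scatter). From the compounds shown here alone, that step ends at a limit, so its true size remains open. The fluoro in place of hydrogen on an aromatic carbon, a change elsewhere in the molecule, gave a 1.3-fold lower number from compound 1 to compound 3 (0.13 log units; within the scatter).

Neither step supports an expected shift beyond the scatter in this assay, although a limit reading is a real possibility for the new compound. The expected change is a 1.1-fold higher number from compound 3 to compound 4 (0.05 log units; within the scatter). For compound 4 the estimate is 16000 nM, with an expected range of 7000 nM to 32000 nM.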

Compound 4, half-maximal inhibitory concentration: > 20000 nM
Compound 4 was reported as a limit; the forecaster's own chance of this, stated with the estimate: 40%; at least 1.2-fold (0.09 log units) between middle value and limit.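

In this assay, replacing 2-fluorophenyl on the aromatic nitrogen with 4-chloro-3-(trifluoromethyl)phenyl gives an at least 1.3-fold higher number from compound 3 to compound 4 (0.14 log units; that floor lies within the scatter); the step rests on a limit, so only its floor can be read, and that floor does not establish a shift. The fluoro-bearing core of compound 4 therefore does not bring this larger aryl group to a measured number. Replacing 2-fluorophenyl has now ended at a limit on both cores shown, once with 3-chlorophenyl and once with this group: the limit of > 20000 nM in this assay, at which 2 of the 4 values shown sit.

From the compounds shown here alone, how far either replacement lies beyond the limit remains open, as does whether the core fluoro has any effect once 2-fluorophenyl has gone. Also open, going by these compounds, is whether an amine or a carboxylic acid on the phenyl ring would give a reading below the limit.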